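Swapping the aryl ketone group on a shared core

A few compounds are considered here, and "the series" means these few. Any claim that something is new, unique, unknown or untested is made for them only; others in the source may bear on it.

Compound 1, `COc1cc(-c2cc(/C=C/C(=O)c3ccc(Cl)c(Cl)c3)[nH]n2)cc(OC)c1OC`, gives in a functional assay on Hs-578T cells (Homo sapiens) for inhibition, read by sulforhodamine B assay, with a stated time of 48 h (a lower number here means a stronger inhibitor of growth, a higher number a weaker inhibitor of growth), a value of > 100000 nM, which is a limit of the assay. Compound 2, `COc1ccc(C(=O)/C=C/c2cc(-c3cc(OC)c(OC)c(OC)c3)n[nH]2)cc1`, gives in this assay a value of > 100000 nM, again a limit of the assay.

Within the data shown here, these two are the only measured compounds, and they differ in one place: a step that the two limits leave unreadable from compound 1 to compound 2. Since both numbers are limits, the size and direction of that step cannot be read. Compound 2 therefore stands only at a limit, with no measured number to place it against; the other value shown is a limit as well, as the limit of > 100000 nM in this assay, at which 2 of the 2 values shown sit, records.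

Compound 3, `COc1cc(-c2cc(/C=C/C(=O)c3ccc(F)c(F)c3)[nH]n2)cc(OC)c1OC`, is not yet measured. It differs from compound 2 by 3,4-difluorophenyl in place of 4-methoxyphenyl on a carbonyl carbon. No readable step bears on this change, so no direction beyond the scatter can be predicted. Compound 3 is expected to remain at or near the limit because the limit of > 100000 nM in this assay, at which 2 of the 2 values shown sit, holds both values shown. The estimate for compound 3 in this assay is 100000 nM, within a range of 30000 nM to 300000 nM, meaning an expected step of a number no higher from compound 2 to compound 3 (the limit leaves the size open).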

Compound 3, concentration for total growth inhibition: 36800 nM
Compound 3: the middle estimate sits 2.7-fold (0.43 log units) above what was measured; the range from low to high includes it.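

Among these compounds, at this position, on a carbonyl carbon whose other neighbour is a double-bonded chain carbon, the earlier compounds gave no readable difference. Among the compounds shown here, compound 3 is the first to show that the aryl group placed here can change growth inhibition in this assay: 3,4-difluorophenyl in place of 4-methoxyphenyl gives an at least 2.7-fold lower number from compound 2 to compound 3 (0.43 log units; beyond the scatter), and 3,4-difluorophenyl in place of 3,4-dichlorophenyl gives an at least 2.7-fold lower number from compound 1 to compound 3 (0.43 log units; beyond the scatter). The second step shows that halogens on this ring are not enough on their own, since the dichloro and difluoro groups do not end up in the same place, and both steps are minimum sizes since the values of compound 1 and compound 2 are limits: the limit of > 100000 nM in this assay, at which 2 of the 3 values shown sit.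

From the compounds shown here alone, the step between compound 1 and compound 2 still cannot be read, so the order of those two remains unknown, and the true size of both new steps stays open. Going by these compounds, it is also open whether both fluorines are needed at this position, and whether a 4-fluorophenyl or a plain phenyl with no substituent on a carbonyl carbon would give a measurable number or fall back to the limit.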